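The compounds below may be only part of what the source reports. "The series", "measured", "known", "first", "only" and "open" are said of these compounds alone.

Working notes on the acylguanidine series. Three compounds have numbers in a functional assay for inhibition of sodium/hydrogen exchanger (Oryctolagus cuniculus); a lower number here means a stronger inhibitor, a higher number a weaker inhibitor: compound 1 `Cc1c(C(=O)N=C(N)N)cc(S(C)(=O)=O)c(C)c1C` gives 55 nM, compound 2 `CCSc1cc(C)c(C(=O)N=C(N)N)cc1S(C)(=O)=O` gives 5.9 nM, and compound 3 `Cc1c(C(=O)N=C(N)N)cc(S(C)(=O)=O)c(Oc2cccnc2)c1C` gives 23 nM. Compound 2 stands lowest of the three; compound 3 is nearest, and compound 1 furthest, both beyond the scatter. For the measured compounds named here, the only single-point step measured so far is a 2.4-fold lower number from compound 1 to compound 3 (0.38 log units; beyond the scatter), a modest change at the carbon ortho to the methylsulfonyl group. Going by the values given here, compound 4 `Cc1cc(N2CCCC2)c(S(C)(=O)=O)cc1C(=O)N=C(N)N` is not yet measured. pyrrolidin-1-yl in place of ethylsulfanyl on an aromatic carbon The change sits at the same carbon as the step from compound 1 to compound 3, but no measured pair exchanges a sulfur-linked chain for a ring-closed amine there, so that step gives only a loose guide: substituents at this carbon have shifted this assay beyond the scatter across the three compounds. For compound 4 the number in this assay is expected to lie near 15 nM, between 4 nM and 60 nM, an expected step of a 2.5-fold higher number from compound 2 to compound 4 (0.41 log units; beyond the scatter).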

Compound 4, half-maximal inhibitory concentration: 11 nM
Compound 4: the middle estimate sits 1.4-fold (0.13 log units) above what was measured, and the stated range covers the measured number.
By their numbers in this assay, from the lowest: compounds 2 and 4 (each within the scatter of the next); then compound 3; then compound 1.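

In this assay the exchange at this carbon, ortho to a methylsulfonyl group, gives a 1.9-fold higher number from compound 2 to compound 4 (0.27 log units; within the scatter), so the two compounds stand within the scatter of each other. Here, a sulfur-linked open chain of 3 heavy atoms and a nitrogen-linked ring of 5 heavy atoms read alike, whereas the earlier exchange at this carbon, on a core with one more methyl group, gave a 2.4-fold lower number from compound 1 to compound 3 (0.38 log units; beyond the scatter), beyond the scatter. No measurement available bears on why the two groups read alike.

From the compounds shown here alone, whether an open-chain amine such as diethylamino, or a larger ring such as piperidin-1-yl or morpholin-4-yl, would also stay within the scatter of compound 2 remains open. Also open, going by these compounds, is how pyrrolidin-1-yl would read on the core of compound 1, with its additional methyl group.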